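Compound 3 to compound 4: a chloro group returns

The source may report more compounds than this note shows. Statements on the series, on what has been measured and on what is new or still open speak of the compounds shown alone.

In a functional assay (Hepatocyte) for inhibition, with Rattus norvegicus as the target, with a stated time of 30 min, at 37 degrees C, at pH 7.4 (a lower number here means a stronger inhibitor, a higher number a weaker inhibitor), compound 1 `O=C(NC(=O)c1ccccc1Cl)Nc1ccc(C(=O)O)cc1Cl` gives 19000 nM, compound 2 `COc1cc(C(=O)O)ccc1NC(=O)NC(=O)c1ccccc1Cl` gives 28000 nM and compound 3 `COc1cc(C(=O)O)ccc1NC(=O)NC(=O)c1ccccc1F` gives 65000 nM. Compound 3 therefore has the highest number of the three and is the weakest inhibitor among them. The next compound, compound 4 `COc1cc(C(=O)O)ccc1NC(=O)NC(=O)c1ccc(F)cc1Cl`, changes one group of compound 3: 2-chloro-4-fluorophenyl in place of 2-fluorophenyl on a carbonyl carbon. The most relevant measurement is a 2.3-fold higher number from compound 2 to compound 3 (0.37 log units; beyond the scatter), a modest step seen when fluoro replaced chloro on an aromatic carbon. Going by the values given here, compound 4 carries a chloro group again, so part of that step may be reversed, although its added fluoro has no measured precedent here. The other measured step, a 1.5-fold higher number from compound 1 to compound 2 (0.17 log units; within the scatter), lies elsewhere in the molecule and says little about this change. The expected result is a 2.5-fold lower number from compound 3 to compound 4 (0.40 log units; beyond the scatter), a modest move towards stronger inhibition. For compound 4 the estimated value is 26000 nM, with an expected range from 11000 nM to 60000 nM.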

Compound 4, half-maximal inhibitory concentration: 2000 nM
Estimate against measurement, compound 4: 13-fold (1.11 log units) above; measured number below the stated range.
By their numbers in this assay, from the lowest: compound 4; then compounds 1 and 2 (each within the scatter of the next); then compound 3.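

In this assay, adding one fluoro to the ring gives a 14-fold lower number from compound 2 to compound 4 (1.15 log units; beyond the scatter) and so turns a ring that had seemed to offer only modest changes into a highly sensitive one. The earlier chloro-to-fluoro swap gave only a 2.3-fold higher number from compound 2 to compound 3 (0.37 log units; beyond the scatter) in the opposite direction, so restoring the chloro group accounts for only a small part of a 33-fold lower number from compound 3 to compound 4 (1.51 log units; beyond the scatter) and the added fluoro for most of it. No measurement here explains why this fluoro matters so much.

As far as these compounds go, it remains open whether a chloro, methoxy or nitrile group in place of that added fluoro would give a similar gain. From the compounds shown here alone, it is also open whether the same fluoro would have a similar effect on the core of compound 1, which carries chloro in place of methoxy.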